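This account rests on a few compounds, and the source may have more. Where it says the series, first, only, none or still open, it means among the compounds named here.

Compound 1 `O=C(CSc1nnc(-c2ccncc2)o1)N/N=C/c1ccc(Cl)cc1`, compound 2 `O=C(CSc1nnc(-c2ccncc2)o1)N/N=C/c1ccc(O)cc1` and compound 3 `O=C(CSc1nnc(-c2ccncc2)o1)N/N=C/c1cc(Br)cc(Br)c1O` share one core and differ only at the aryl on the carbon with a double bond to nitrogen. In a functional assay on MCF7 cells (Homo sapiens) for cytotoxicity, read by MTT assay, with a stated time of 48 h (a lower number here means a stronger inhibitor, a higher number a weaker inhibitor), compound 1 gives 15300 nM, the highest of the three numbers, while compound 2 gives 11700 nM and compound 3 gives 9010 nM; all three steps, a 1.3-fold lower number from compound 1 to compound 2 (0.12 log units; within the scatter), a 1.7-fold lower number from compound 1 to compound 3 (0.23 log units; within the scatter) and a 1.3-fold lower number from compound 2 to compound 3 (0.11 log units; within the scatter), lie within the scatter. Compound 4 `COc1cc(/C=N/NC(=O)CSc2nnc(-c3ccncc3)o2)ccc1O` is not yet measured. Relative to compound 1 the change is 4-hydroxy-3-methoxyphenyl in place of 4-chlorophenyl on a carbon with a double bond to nitrogen. Going by the values given here, the nearest precedent is a 1.3-fold lower number from compound 1 to compound 2 (0.12 log units; within the scatter), which also exchanges chloro for hydroxy at this aryl; nothing beyond the scatter is expected. Compound 4 is therefore estimated at 11500 nM in this assay, range 5500 nM to 24000 nM, a step of a 1.3-fold lower number from compound 1 to compound 4 (0.12 log units; within the scatter) expected.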

Compound 4, half-maximal inhibitory concentration: 3780 nM
For compound 4 the middle estimate is 3.0-fold (0.48 log units) above the measured one; measured number outside the range, below it.
By their numbers in this assay, from the lowest: compound 4; then compounds 3, 2 and 1 (each within the scatter of the next).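

In this assay the aryl on the carbon with a double bond to nitrogen now gives steps beyond the scatter, with 4-hydroxy-3-methoxyphenyl as the entering group (a 4.0-fold lower number from compound 1 to compound 4 (0.61 log units; beyond the scatter)) (a 2.4-fold lower number from compound 3 to compound 4 (0.38 log units; beyond the scatter)). The single added methoxy in place of hydrogen on an aromatic carbon accounts for a step of similar standing (a 3.1-fold lower number from compound 2 to compound 4 (0.49 log units; beyond the scatter)), whereas the exchanges among compound 1, compound 2 and compound 3 stayed within the scatter. Nothing measured here explains this step. Open, as far as these compounds go, is whether methoxy needs the hydroxy alongside it, and whether ethoxy or a dimethylamino group would do the same.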